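Chloro in Place of Iodo on the Anilino Ring

This account rests on a few compounds, and the source may have more. Where it says the series, first, only, none or still open, it means among the compounds named here.

For the measured compounds named here, compound 2 `O=C(C1=C(Nc2ccc(I)cc2)C(=O)N(CCCn2ccnc2)C1c1ccc(Br)cc1)c1ccccc1` is one of two compounds so far measured in a functional assay on SAOS-2 cells (Homo sapiens) for antiproliferative activity, read by MTT assay, with a stated time of 72 h; on this read-out lower numbers stand for stronger inhibition and higher numbers for weaker inhibition; in this assay compound 2 gives 23400 nM. The other, compound 1 `O=C(C1=C(OC2CCCCC2)C(=O)N(CCCn2ccnc2)C1c1ccc(Br)cc1)c1ccccc1`, gives 29700 nM in this assay. Going by the values given here, the single measured step, a 1.3-fold lower number from compound 1 to compound 2 (0.10 log units; within the scatter), exchanges cyclohexyloxy for (4-iodophenyl)amino on a double-bonded ring carbon, and it leaves the two numbers within the scatter of each other, so compound 2 is not set apart from compound 1 on what has been measured.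

Compound 3 `O=C(C1=C(Nc2ccc(Cl)cc2)C(=O)N(CCCn2ccnc2)C1c1ccc(Br)cc1)c1ccccc1` has not yet been measured. It differs from compound 2 by chloro in place of iodo on an aromatic carbon, para to a large group. Among the compounds with values here, no measured step bears directly on an exchange of one halogen for another; the only available step, a 1.3-fold lower number from compound 1 to compound 2 (0.10 log units; within the scatter), alters a different part of the shared core and was itself within the scatter. Compound 3 is therefore expected to show no step beyond the scatter, a 1.1-fold higher number from compound 2 to compound 3 (0.03 log units; within the scatter). Compound 3 is estimated at 25000 nM in this assay, with an expected range from 9000 nM to 70000 nM.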

Compound 3, half-maximal inhibitory concentration: 24800 nM
For compound 3 the middle estimate is 1.0-fold (0.00 log units) above the measured one; the measured number falls inside the stated range.
By their numbers in this assay, from the lowest: compounds 2, 3 and 1 (each within the scatter of the next).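

In this assay, for the compounds shown here, the first exchange of one halogen for another on the anilino ring, on an aromatic carbon para to a large group, gives a 1.1-fold higher number from compound 2 to compound 3 (0.03 log units; within the scatter), so iodo and chloro at this position are not told apart on this read-out. The exchange on the double-bonded ring carbon, now read a second time with a different halogen in the incoming group, gives a 1.2-fold lower number from compound 1 to compound 3 (0.08 log units; within the scatter), so (4-chlorophenyl)amino, like (4-iodophenyl)amino, does not set its compound apart from the cyclohexyloxy compound 1. Nothing available on these compounds speaks to what lies behind these results.

Since every step among the three compounds lies within the scatter, they do not show whether any part of the shared core can move this read-out at all. Open, therefore, is whether a group of another kind at the same aromatic carbon, such as a methoxy group, an amine or a carboxylic acid, or a change to the bromo group elsewhere on the shared core, would give a step beyond the scatter.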